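Methoxyphenyl sulfonyl series: from compound 2 to compound 3

The source may hold more compounds than are shown below. What is called first, only, known or untested is meant among the compounds shown, and "the series" means these compounds.

Measured in a functional assay on MDA-MB-231 cells (Homo sapiens) for antiproliferative activity, read by MTT assay, with a stated time of 24 h; on this read-out lower numbers stand for stronger inhibition and higher numbers for weaker inhibition:
- compound 1 (`CC(C)(C)c1ccc(S(=O)(=O)N2CCN(c3nccc(Oc4cc(Cl)cc(Cl)c4)n3)CC2)cc1`): > 50000 nM
- compound 2 (`COc1ccccc1S(=O)(=O)N1CCN(c2nccc(Oc3cc(Cl)cc(Cl)c3)n2)CC1`): 16800 nM

Only compound 2 has an actual number in this assay, at 16800 nM. For compound 1 the entry of > 50000 nM is a limit and not a number.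

For the measured compounds named here, the one measured step is an at least 2.9-fold lower number from compound 1 to compound 2 (0.47 log units; beyond the scatter). Its size is open-ended, as it rests on (the limit of > 50000 nM in this assay, at which 1 of the 2 values shown sits). It swaps the whole group on the sulfonyl sulfur, so it bears only in part on what comes next.

Compound 3 (`COc1ccc(S(=O)(=O)N2CCN(c3nccc(Oc4cc(Cl)cc(Cl)c4)n3)CC2)cc1`) has the same atoms as compound 2, joined differently: 4-methoxyphenyl in place of 2-methoxyphenyl on a sulfonyl sulfur, with 4-methoxyphenyl in place of 2-methoxyphenyl on a sulfonyl sulfur. Going by the values given here, no measured step isolates this change. The only hint is an at least 2.9-fold lower number from compound 1 to compound 2 (0.47 log units; beyond the scatter), where the 2-methoxyphenyl compound carries the lower number. A small move towards a higher number is therefore expected, not clearly beyond the scatter. The expected move is a 1.5-fold higher number from compound 2 to compound 3 (0.17 log units; within the scatter). Compound 3 is estimated at 25000 nM. The expected range for compound 3 runs from 10000 nM to 50000 nM.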

Compound 3, half-maximal inhibitory concentration: 46800 nM
For compound 3 the middle estimate is 1.9-fold (0.27 log units) below the measured one; the measured number falls inside the stated range.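

In this assay, 4-methoxyphenyl in place of 2-methoxyphenyl on a sulfonyl sulfur gives a 2.8-fold higher number from compound 2 to compound 3 (0.44 log units; beyond the scatter). The earlier step exchanged the whole group on the sulfonyl sulfur, whereas this one keeps the same atoms and changes only how they are joined, so it shows that the place of the methoxy group on the phenyl ring alone moves the read-out, with the 2-methoxyphenyl compound carrying the lower number of this pair. The entry for compound 1 of > 50000 nM is a limit and not a number. Methoxy in place of tert-butyl on an aromatic carbon gives an at least 1.0-fold lower number from compound 1 to compound 3 (0.02 log units; that floor lies within the scatter) and this step is open-ended: the limit of > 50000 nM in this assay, at which 1 of the 3 values shown sits.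

The two methoxyphenyl compounds show only that the two placements differ, and they leave open whether the methoxy group itself contributes, since a plain phenyl on the sulfonyl sulfur would be needed to set a reference for both. On these data alone, whether a group such as an amine or a carboxylic acid on that phenyl ring would bring the number in this assay below that of compound 2, at 16800 nM, also remains open.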